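Hydroxythiosemicarbazone series: cytotoxicity working notes

A few compounds are considered here, and "the series" means these few. Any claim that something is new, unique, unknown or untested is made for them only; others in the source may bear on it.

Compound 1 `CCn1cc(C(=O)O)c(=O)c2cc(F)c(N3CCN(CN4C(=O)/C(=N\NC(=S)NO)c5cc(C)ccc54)C(C)C3)c(F)c21`: in an ADME assay on MT4 cells (Homo sapiens) for cytotoxicity, read by spectrophotometry, with a stated time of 5 days (on this read-out lower numbers stand for higher toxicity in this test and higher numbers for lower toxicity in this test), compound 1 gives 244000 nM.
Compound 2 `COc1ccc(N2CCN(CN3C(=O)/C(=N\NC(=S)NO)c4cc(Cl)ccc43)CC2)cc1`: in this assay compound 2 gives 279000 nM.
Compound 3 `CCn1cc(C(=O)O)c(=O)c2cc(F)c(N3CCN(CN4C(=O)/C(=N\NC(=S)NO)c5cc(Cl)ccc54)C(C)C3)c(F)c21`: in this assay compound 3 gives 209000 nM.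

Compounds 1 and 3 share one core; compound 2 carries another, and the difference between the two cores is not broken down here. The change from compound 3 to compound 1 is methyl in place of chloro on an aromatic carbon, and in this assay it gave a 1.2-fold higher number from compound 3 to compound 1 (0.07 log units; within the scatter). Compound 2 lies within the scatter of both of the other two, so no ordering among the three is read.

Compound 4 `COc1ccc(N2CCN(CN3C(=O)/C(=N\NC(=S)NO)c4cc(C)ccc43)CC2)cc1` applies the same change to the core of compound 2: methyl in place of chloro on an aromatic carbon. Because a 1.2-fold higher number from compound 3 to compound 1 (0.07 log units; within the scatter) stayed within the scatter, the expected step here is likewise small: a 1.1-fold higher number from compound 2 to compound 4 (0.06 log units; within the scatter). Compound 4 is therefore estimated at 320000 nM, expected to fall between 160000 nM and 640000 nM.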

Compound 4, half-maximal cytotoxic concentration: 321000 nM
Beside the measured number, compound 4's estimate is 1.0-fold (0.00 log units) below it; measured number inside the range.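

In this assay the step of a 1.2-fold higher number from compound 2 to compound 4 (0.06 log units; within the scatter) comes with methyl in place of chloro on an aromatic carbon, on the core of compound 2. Set beside the step on the core of compound 1, the change reads the same on both cores: the same change on two cores in this assay, a 1.2-fold higher number (0.07 log units; within the scatter) from compound 3 to compound 1 and a 1.2-fold higher number (0.06 log units; within the scatter) from compound 2 to compound 4, 1.0-fold (0.01 log units) apart, within the scatter of two such steps

This shows that the change carried from one core to the other with no readable difference in this one cytotoxicity read-out. Both steps lie within the scatter, so it does not show that the change has an effect of its own, and it says nothing about any other core.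

The compounds shown cover only chloro and methyl at this aromatic carbon. Going by these compounds, what a nitrile or an amine there would give remains open, on either core.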